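Hydroxamic acid to aminophenyl amide across two linkers

This account rests on a few compounds, and the source may have more. Where it says the series, first, only, none or still open, it means among the compounds named here.

In a functional assay on MC-38 cells (Mus musculus) for antiproliferative activity, read by CCK-8 assay, with a stated time of 72 h (a lower number here means a stronger inhibitor of growth, a higher number a weaker inhibitor of growth), compound 1 `Nc1nc(NCCCc2ccc(C(=O)NO)cc2)nc2nc(-c3ccco3)nn12` reaches only the limit of the assay, > 100000 nM. Compound 2 `Nc1nc(NCCOc2ccc(C(=O)NO)cc2)nc2nc(-c3ccco3)nn12` likewise gives only the limit > 100000 nM; the difference between the two cores is not broken down here. Compound 3 `Nc1ccccc1NC(=O)c1ccc(CCCNc2nc(N)n3nc(-c4ccco4)nc3n2)cc1` gives 25400 nM in this assay, a step of an at least 3.9-fold lower number from compound 1 to compound 3 (0.59 log units; beyond the scatter); that step is open at one end due to the limit of > 100000 nM in this assay, at which 2 of the 3 values shown sit. The change is 2-aminophenyl in place of hydroxy on an amide-type nitrogen, and compound 4 `Nc1ccccc1NC(=O)c1ccc(OCCNc2nc(N)n3nc(-c4ccco4)nc3n2)cc1` carries the same change on the core of compound 2, namely (2-aminophenyl in place of hydroxy on an amide-type nitrogen). Given the step from compound 1 to compound 3, a step of comparable size is expected on the second core. Compound 4 is expected to give about 30000 nM in this assay, between 8000 nM and 100000 nM. That corresponds to an expected step of an at least 3.3-fold lower number from compound 2 to compound 4 (0.52 log units; beyond the scatter).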

Compound 4, concentration for 50% growth inhibition: 36900 nM
Estimate against measurement, compound 4: 1.2-fold (0.09 log units) below, and the stated range covers the measured number.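

In this assay the change from hydroxy to 2-aminophenyl on an amide-type nitrogen also lowers the number on the second core, with an at least 2.7-fold lower number from compound 2 to compound 4 (0.43 log units; beyond the scatter). Set beside the first core, the two steps compare as follows: the same change on two cores in this assay, an at least 3.9-fold lower number (0.59 log units; beyond the scatter) from compound 1 to compound 3 and an at least 2.7-fold lower number (0.43 log units; beyond the scatter) from compound 2 to compound 4; the limit leaves it open whether they differ. As far as these compounds go, the direction of the change therefore carries over between these two cores, but its true size on either core remains unknown, and two cores are too few to show a general rule: the limit of > 100000 nM in this assay, at which 2 of the 4 values shown sit.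

The compounds shown leave open whether a plain phenyl on the same nitrogen would give a comparable step. They also leave open whether the change would carry over to a core with a longer chain.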